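The compounds below may be only part of what the source reports. "The series", "measured", "known", "first", "only" and "open" are said of these compounds alone.

Measured in a functional assay (brain) for inhibition, with Rattus norvegicus as the target; on this read-out higher numbers stand for weaker inhibition and lower numbers for stronger inhibition:
- compound 1 `CCCCCCCCCCCCOC1=C(O)OC(C(O)CO)C1=O`: 54000 nM
- compound 2 `CCCCCCCCCCCCCCOC1=C(O)OC(C(O)CO)C1=O`: 7400 nM
- compound 3 `CCCCCCCCCCCCCCCOC1=C(O)OC(C(O)CO)C1=O`: 5600 nM

Compound 3 has the lowest number of the three, but its gap to compound 2 lies within the scatter; only compound 1 stands clearly apart. Compound 4 `CCCCCCCCCCCCCCCCCCCCOC1=C(O)OC(C(O)CO)C1=O` has pentyl in place of hydrogen on a saturated chain carbon, ten or more bonds along the chain from an oxygen on an unsaturated carbon.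

The three measured chain extensions all bear on this change. The two starting from the shortest chain gave a 7.3-fold lower number from compound 1 to compound 2 (0.86 log units; beyond the scatter) and a 9.6-fold lower number from compound 1 to compound 3 (0.98 log units; beyond the scatter). The extension among the longer chains gave only a 1.3-fold lower number from compound 2 to compound 3 (0.12 log units; within the scatter). The pentyl extension goes further than any of these, so the series gives no direct view of this chain length, and the range must stay wide. Going by the small step to compound 3, no change beyond the scatter is expected. The expected step is a 1.1-fold lower number from compound 3 to compound 4 (0.05 log units; within the scatter). For compound 4 the estimated value is 5000 nM, with an expected range of 1500 nM to 20000 nM.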

Compound 4, half-maximal inhibitory concentration: 4700 nM
Estimate against measurement, compound 4: 1.1-fold (0.03 log units) above, within the range that was stated.
By their numbers in this assay, from the lowest: compounds 4, 3 and 2 (each within the scatter of the next); then compound 1.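

In this assay, the pentyl extension on the saturated chain carbon gives a 1.2-fold lower number from compound 3 to compound 4 (0.08 log units; within the scatter), and even the larger hexyl extension gives only a 1.6-fold lower number from compound 2 to compound 4 (0.20 log units; within the scatter), so the flat stretch hinted at by compound 2 and compound 3 now holds over a much greater chain length. Compound 1 alone stands outside this stretch: the octyl extension gives an 11-fold lower number from compound 1 to compound 4 (1.06 log units; beyond the scatter), and the step remains beyond the scatter only when the shortest chain is the starting point. No supporting data bear on the reason for this flat stretch.

On these data alone, whether a longer chain than that of compound 4 keeps the number level stays open, as does the effect of a chain carrying an amine or a carboxylic acid. All the compounds shown carry the shared core unchanged, so its contribution also stays open.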